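Amide swap on a shared core in a whole-animal dose assay

The compounds below may be only part of what the source reports. "The series", "measured", "known", "first", "only" and "open" are said of these compounds alone.

Measured compounds:
- compound 1 `CN(C)C(=O)Cn1c(-c2cccc(Cl)c2)nc2cccnc21`: > 56.2 mg/kg; < 100 mg/kg (2 entries)
- compound 2 `CN(C)C(=O)Cn1c(-c2ccsc2)nc2cccnc21`: 38 mg/kg
- compound 3 `O=C(Cn1c(-c2ccc(Cl)cc2)nc2cccnc21)N1CCCC1`: 17.9 mg/kg

Of the compounds shown here, three on a shared core have been tested in a functional assay on the whole organism with Mus musculus as the target; a higher number here means that more compound is needed for the effect, a lower number that less compound is needed. For compound 1 the result is a limit of the assay, recorded twice, not a number: > 56.2 mg/kg; < 100 mg/kg (2 entries). Compound 2 gives 38 mg/kg. Compound 3 gives 17.9 mg/kg, the lowest dose among the numbers shown; compound 2 lies beyond the scatter from it.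

As far as these compounds go, compound 4 `CN(C)CCNC(=O)Cn1c(-c2ccc(Cl)cc2)nc2cccnc21` is untested in this assay. It differs from compound 3 in one place: (2-(dimethylamino)ethyl)amino in place of pyrrolidin-1-yl on a carbonyl carbon. For the measured compounds named here, no measured pair shows such a change here, so no step size is known. Compound 4 is expected to stay close to compound 3, with the step of a 1.3-fold higher number from compound 3 to compound 4 (0.13 log units; within the scatter) lying within the scatter or little beyond it. For compound 4 the estimated value is 24 mg/kg, with a range from 9 mg/kg to 60 mg/kg.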

Compound 4, dose for half-maximal effect: 62 mg/kg
The estimate for compound 4 lay 2.6-fold (0.41 log units) below the measured number; measured number above the stated range.
By their numbers in this assay, from the lowest: compound 3; then compounds 2 and 4 (each within the scatter of the next).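

In this assay, putting (2-(dimethylamino)ethyl)amino in place of pyrrolidin-1-yl on a carbonyl carbon gives a 3.5-fold higher number from compound 3 to compound 4 (0.54 log units; beyond the scatter), the first step read at this position, and it shows that the dose responds to the group placed here. The change is therefore not neutral, and the open chain with its amide hydrogen requires more compound than the pyrrolidin-1-yl ring. Nothing measured here accounts for this step.

The pair does not separate the effect of the amide hydrogen from that of the terminal dimethylamino group. As far as these compounds go, a piperidine ring or a plain ethylamino group on the same carbonyl carbon remains open.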